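This account rests on a few compounds, and the source may have more. Where it says the series, first, only, none or still open, it means among the compounds named here.

Among the three compounds measured in a functional assay on MCF7 cells (Homo sapiens) for cytotoxicity, read by MTT assay, with a stated time of 72 h (a higher number here means a weaker inhibitor, a lower number a stronger inhibitor), compound 3 `O=C(CCl)Nc1ccc(C(=O)/C=C/c2ccc(Cl)cc2)cc1` stands lowest: compound 3 gives 4100 nM, while its nearest neighbour, compound 2 `CCCCCCCCCCCCCCSC(=S)N[C@H]1CCOC1=O`, gives 30500 nM. Compound 1 `CCCCCCSC(=S)N[C@H]1CCOC1=O` reaches only a limit in this assay, > 128000 nM, and that limit is one at which a single value sits (the limit of > 128000 nM in this assay, at which 1 of the 3 values shown sits). For the measured compounds named here, the one step between measured compounds that differ in a single place is an at least 4.1-fold lower number from compound 1 to compound 2 (0.62 log units; beyond the scatter), a change on a long saturated chain in a core that compound 3 does not share.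

Compound 4 `O=C(CCl)Nc1ccc(C(=O)/C=C/c2ccccc2)cc1` differs from compound 3 by hydrogen in place of chloro on an aromatic carbon, placed on an aromatic carbon of a six-membered aromatic ring of carbon only, para to a large group; cut one bond further out, the change reads 4-chlorophenyl to phenyl. Going by the values given here, no measured step touches this kind of change, and the measured step concerns a different core altogether, so there is nothing here from which a clear direction can be read. The expectation for this assay is therefore a step no larger than the scatter, a 1.5-fold higher number from compound 3 to compound 4 (0.17 log units; within the scatter), leaning toward a slightly higher number. Compound 4 is thus estimated at 6000 nM, within a range from 2500 nM to 15000 nM.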

Compound 4, half-maximal inhibitory concentration: 2480 nM
Compound 4: the middle estimate sits 2.4-fold (0.38 log units) above what was measured; measured number outside the range, below it.
By their numbers in this assay, from the lowest: compounds 4 and 3 (each within the scatter of the next); then compound 2. At a limit, above all of these: compound 1.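

In this assay, for the compounds shown here, the 4-chlorophenyl to phenyl change gives a 1.7-fold lower number from compound 3 to compound 4 (0.22 log units; within the scatter) and is the first measured change on this core, whereas the earlier step concerned a long saturated chain on a different core. The two compounds cannot be told apart here, so the chloro on this aromatic carbon, para to a large group, is not needed for the level of cytotoxicity seen, and hydrogen serves equally well at this place. None of the information available here offers a reason for this result.

Going by these compounds, only hydrogen and chloro have been compared at this position, so it remains open whether a larger or very different group, such as methoxy, an amine or a carboxylic acid, would shift the number beyond the scatter. On these data alone, it also remains open whether a change elsewhere on the shared core, such as a plain acetyl group in place of the chloroacetyl group, would matter more than the change at this position.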